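Swapping the side group on a shared core for a dichlorophenyl

The source may report more compounds than this note shows. Statements on the series, on what has been measured and on what is new or still open speak of the compounds shown alone.

Compound 2, `O=C(c1ccc(-c2nc(Cc3cccs3)no2)s1)C(F)(F)F`: 170 nM
Compound 1, `O=C(c1ccc(-c2ncc(-c3ccccc3)s2)s1)C(F)(F)F`: 1350 nM
Compound 3, `O=C(c1ccc(-c2nc(-c3cccc(C(F)(F)F)c3)no2)s1)C(F)(F)F`: 2450 nM

In an assay on isolated protein for inhibition of protein deacetylase HDAC6 (Homo sapiens) (a higher number here means a weaker inhibitor, a lower number a stronger inhibitor), compound 2 gives the lowest of the three numbers. Its nearest neighbour is compound 1 at 1350 nM, a gap beyond the scatter, and the furthest is compound 3 at 2450 nM, also beyond the scatter.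

The unmeasured compound 4, `O=C(c1ccc(-c2nc(-c3ccc(Cl)cc3Cl)no2)s1)C(F)(F)F`, differs from compound 2 by one change: 2,4-dichlorophenyl in place of (thiophen-2-yl)methyl on an aromatic carbon. Going by the values given here, no directly comparable step has been measured, so the expectation rests on the spread of the three values. Compound 3 also bears a six-membered aromatic ring of carbon only at the same place and gives 2450 nM, so a weakening step is expected for compound 4, clearly beyond the scatter. This expectation amounts to a step of an 8.8-fold higher number from compound 2 to compound 4 (0.95 log units; beyond the scatter) in this assay. For compound 4 the estimated value in this assay is 1500 nM, with a range from 450 nM to 5000 nM.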

Compound 4, half-maximal inhibitory concentration: 3000 nM
Estimate against measurement, compound 4: 2.0-fold (0.30 log units) below; measured number inside the range.
By their numbers in this assay, from the lowest: compound 2; then compounds 1, 3 and 4 (each within the scatter of the next, the first and the last beyond it).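

In this assay, putting 2,4-dichlorophenyl in place of (thiophen-2-yl)methyl on the aromatic carbon between two ring nitrogen atoms gives an 18-fold higher number from compound 2 to compound 4 (1.25 log units; beyond the scatter), the first large step read directly at this position. Going by these compounds alone, compound 3, which also carries a six-membered aromatic ring of carbon only at this place, gives 2450 nM and compound 4 gives 3000 nM, two values within the scatter of each other, so among the three compounds at this place only the one with (thiophen-2-yl)methyl gives the low number. Nothing available here accounts for the step.

The change swaps the ring and removes the methylene link at once, so the step cannot be assigned to either alone. A benzyl group or a directly attached thiophen-2-yl group at this place would separate the two.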